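The source may report more compounds than this note shows. Statements on the series, on what has been measured and on what is new or still open speak of the compounds shown alone.

In a functional assay on CHO-RD-HGA16 cells for agonist activity at Orexin/Hypocretin receptor type 1 (Homo sapiens), read by fluorescence and calcium flux, with a stated time of 30 min (a higher number here means that more compound is needed for the effect, a lower number that less compound is needed), compound 1 `COc1ccc(-c2csc(C(=O)N(C)C)c2)cc1S(=O)(=O)Nc1cccc(NCCNC(=O)c2cccc(C)c2)c1` gives 1330 nM, while compound 2 `COc1ccc(-c2cccc(C(=O)N(C)CCN(C)C)c2)cc1S(=O)(=O)Nc1cccc(NCCNC(=O)c2cccc(C)c2)c1` gives 638 nM, the lowest of the two numbers and beyond the scatter away from compound 1. Compound 3 `COc1ccc(-c2cccc(C(=O)NCCN(C)C)c2)cc1S(=O)(=O)Nc1cccc(NCCNC(=O)c2cccc(C)c2)c1` differs from compound 2 only by hydrogen in place of methyl on an amide-type nitrogen. Among the measured compounds shown here, no measured pair shows this change, so its effect is unknown from the data; the step of a 1.2-fold higher number from compound 2 to compound 3 (0.07 log units; within the scatter) is expected to be small, within the scatter, with no clear direction. In this assay compound 3 is therefore estimated at 750 nM, with a range from 250 nM to 2200 nM.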

Compound 3, half-maximal effective concentration: > 10000 nM
Compound 3: no number, only a limit (the forecaster's own chance of this, stated with the estimate: 10%); at least 13-fold (1.12 log units) between middle value and limit.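

On the amide-type nitrogen, the methyl matters in this assay: hydrogen in its place gives an at least 15-fold higher number from compound 2 to compound 3 (1.19 log units; beyond the scatter). Compound 1 and compound 2 differ in more than one place and could not show that this single carbon carries so much weight. The step is a bound rather than a number, and compound 3 stands at a limit of the assay: the limit of > 10000 nM in this assay, at which 1 of the 3 values shown sits.

Going by these compounds, whether an ethyl group or a longer chain on that nitrogen would keep the number of compound 2 stays open. So does whether the same change would act alike without the dimethylamino group at the end of the chain.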